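This account rests on a few compounds, and the source may have more. Where it says the series, first, only, none or still open, it means among the compounds named here.

Compound 1 `O=C(/C=C/c1ccc(O)c(O)c1)OCc1c(-c2ccccc2)no[n+]1[O-]` and compound 2 `COc1cc(/C=C/C(=O)OCc2c(-c3ccccc3)no[n+]2[O-])ccc1O` share one core and differ by methyl in place of hydrogen on an oxygen on an aromatic ring. In a functional assay on NCI-H1792 cells (Homo sapiens) for cytotoxicity, read by resazurin assay, with a stated time of 72 h (a higher number here means a weaker inhibitor, a lower number a stronger inhibitor), compound 1 gives 3780 nM. In this assay compound 2 gives 11100 nM. The measured step is a 2.9-fold higher number from compound 1 to compound 2 (0.47 log units; beyond the scatter).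

Compound 3 `O=C(/C=C/c1ccc(OCCCCCCO[N+](=O)[O-])c(O)c1)OCCCCCCO[N+](=O)[O-]` is built on a different core, and how the two cores differ is not broken down here. In this assay compound 3 reaches only a limit of the assay, > 50000 nM, so no number is known for it. Compound 4 `COc1cc(/C=C/C(=O)OCCCCCCO[N+](=O)[O-])ccc1OCCCCCCO[N+](=O)[O-]` differs from compound 3 by methyl in place of hydrogen on an oxygen on an aromatic ring, the same change that separates compound 1 from compound 2.

Compound 3 already sits at the limit of > 50000 nM in this assay, at which 1 of the 3 values shown sits, and the earlier step ran toward a higher number, so compound 4 is expected to stay at or past that limit. Compound 4 is expected to show a step that the limit leaves unreadable from compound 3 to compound 4 because a 2.9-fold higher number from compound 1 to compound 2 (0.47 log units; beyond the scatter) ran the same way. The estimate for compound 4 is 120000 nM, with a range from 50000 nM to 400000 nM.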

Compound 4, half-maximal inhibitory concentration: > 50000 nM
Compound 4: no number, only a limit; the forecaster's own chance of this, stated with the estimate: 85%; the middle value does not contradict the limit.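

In this assay compound 3 gives > 50000 nM, which is a limit of the assay and not a number. In this assay compound 4 gives > 50000 nM, also a limit, so no step can be read between compound 3 and compound 4. The compounds shown leave open how large the effect of hydroxy to methoxy is on the core of compound 3.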